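The source may report more compounds than this note shows. Statements on the series, on what has been measured and on what is new or still open speak of the compounds shown alone.

For the measured compounds named here, in a functional assay on A549 cells (Homo sapiens) for inhibition, read by MTT assay, with a stated time of 48 h (a higher number here means a weaker inhibitor, a lower number a stronger inhibitor), compound 1 `Cc1ccc(-c2nc3ccccn3c2Sc2ccccc2)cc1` gives 94300 nM, the higher of the two numbers measured so far, which makes it the weaker of the pair. Compound 2 `Cc1ccc(-c2nc3ccc(C)cn3c2Sc2ccccc2)cc1` gives 23800 nM. Going by the values given here, the only measured step, a 4.0-fold lower number from compound 1 to compound 2 (0.60 log units; beyond the scatter), is modest and comes from methyl in place of hydrogen on an aromatic carbon. Compound 3 `c1ccc(Sc2c(-c3ccsc3)nc3ccccn23)cc1` has not yet been measured. It carries thiophen-3-yl in place of 4-methylphenyl on an aromatic carbon, (thiophen-3-yl in place of 4-methylphenyl on an aromatic carbon). Among the compounds with values here, the measured step leaves the 4-methylphenyl group untouched, so it bears on this exchange only indirectly, and no measured step tests it. On these data alone, no step beyond the scatter is therefore expected in this assay, and the direction remains open. The expected step, a 1.1-fold lower number from compound 1 to compound 3 (0.05 log units; within the scatter), is correspondingly small. For compound 3 the estimate is 85000 nM, with an expected range from 30000 nM to 240000 nM.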

Compound 3, half-maximal inhibitory concentration: 72900 nM
Beside the measured number, compound 3's estimate is 1.2-fold (0.07 log units) above it, within the range that was stated.
By their numbers in this assay, from the lowest: compound 2; then compounds 3 and 1 (each within the scatter of the next).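

In this assay, for the compounds shown here, the exchange of 4-methylphenyl for thiophen-3-yl gives a 1.3-fold lower number from compound 1 to compound 3 (0.11 log units; within the scatter) and is the first reading at this position. A five-membered aromatic ring with one sulfur and fewer heavy atoms, carrying one hydrogen-bond acceptor, thus stands in for the six-membered carbon ring on this aromatic carbon with no change beyond the scatter. No available evidence accounts for this result.

The compounds shown leave open whether this position would tolerate a group of another kind, such as an aminomethyl group, a carboxylic acid or a longer alkyl chain on the aromatic ring. They also leave open whether thiophen-3-yl at this position would combine with the methyl group that gave a 4.0-fold lower number from compound 1 to compound 2 (0.60 log units; beyond the scatter) to keep that step.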